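A few compounds are considered here, and "the series" means these few. Any claim that something is new, unique, unknown or untested is made for them only; others in the source may bear on it.

Measured compounds:
compound 1, `N#Cc1cc(F)cc(C#Cc2cccc(F)n2)c1`, gives 41 nM
compound 2, `CC(=O)c1cccc(C#Cc2cc(F)cc(C#N)c2)n1`, gives 64 nM
compound 3, `N#Cc1cccc(C#Cc2cccc(F)n2)c1`, gives 150 nM

All three values come from an assay on membranes from brain (strain Sprague-Dawley) for displacement of a labelled ligand from metabotropic glutamate receptor 5 (Rattus norvegicus), read by scintillation counting, with a stated time of 60 min; a higher number here means a weaker inhibitor, a lower number a stronger inhibitor. The change acetyl in place of fluoro on an aromatic carbon produced a 1.6-fold higher number from compound 1 to compound 2 (0.19 log units; within the scatter). The change hydrogen in place of fluoro on an aromatic carbon produced a 3.7-fold higher number from compound 1 to compound 3 (0.56 log units; beyond the scatter); this is also how the core of compound 3 differs from the core of compound 1. Compound 4, `CC(=O)c1cccc(C#Cc2cccc(C#N)c2)n1`, has not been measured in this assay. It differs from compound 3 by acetyl in place of fluoro on an aromatic carbon, which is the same change as from compound 1 to compound 2, at a place described in the same words. For compound 4 a step of a 1.6-fold higher number from compound 3 to compound 4 (0.20 log units; within the scatter) is expected, resting on the earlier step of a 1.6-fold higher number from compound 1 to compound 2 (0.19 log units; within the scatter) applied to compound 3 at 150 nM. Compound 4 is therefore estimated at 240 nM in this assay, with a range from 120 nM to 480 nM.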

Compound 4, inhibition constant: 114 nM
Estimate against measurement, compound 4: 2.1-fold (0.32 log units) above, outside the stated range (below it).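

In this assay, acetyl in place of fluoro gives a 1.3-fold lower number from compound 3 to compound 4 (0.12 log units; within the scatter), and this agrees with the earlier step on the other core: the same change on two cores in this assay, a 1.6-fold higher number (0.19 log units; within the scatter) from compound 1 to compound 2 and a 1.3-fold lower number (0.12 log units; within the scatter) from compound 3 to compound 4, 2.1-fold (0.31 log units) apart, within the scatter of two such steps

Hydrogen in place of fluoro gives a 1.8-fold higher number from compound 2 to compound 4 (0.25 log units; within the scatter), which also agrees with its earlier counterpart: the same change on two cores in this assay, a 3.7-fold higher number (0.56 log units; beyond the scatter) from compound 1 to compound 3 and a 1.8-fold higher number (0.25 log units; within the scatter) from compound 2 to compound 4, 2.1-fold (0.31 log units) apart, within the scatter of two such steps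

Among these compounds, both changes therefore carry between these cores as far as can be read, but with only two steps for each change, this does not show that either has a fixed size on other cores.

The compounds shown leave open how an amine, a carboxylic acid or a longer chain would behave in the place of the acetyl. Replacement of the nitrile, for example by chlorine, also remains open.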